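A few compounds are considered here, and "the series" means these few. Any claim that something is new, unique, unknown or untested is made for them only; others in the source may bear on it.

Measured compounds:
Compound 1 `CCn1c(=O)n(C2OC(CO)[C@@H](O)[C@H]2O)c2nc(N)nc(O)c21` — 15 uM
Compound 2 `C=CCSc1nc2c(O)nc(N)nc2n1C1OC(CO)[C@@H](O)[C@H]1O` — 107 uM

In a functional assay (B cells) with Mus musculus as the target (a higher number here means that more compound is needed for the effect, a lower number that less compound is needed), compound 1 gives 15 uM, the lower of the two numbers recorded. Compound 2, which carries a different substitution pattern on the shared core, gives 107 uM in this assay, a higher number that lies beyond the usual scatter of the measurement. The two compounds differ in more than one place, so their gap is noted only as what the two values show, without a single counted step between them.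

Compound 3 `Nc1nc(O)c2c(n1)n(C1OC(CO)[C@@H](O)[C@H]1O)c(=O)n2CC(O)CO` has not yet been measured in this assay. It differs from compound 1 in one place:

1,2-dihydroxyethyl in place of methyl on a saturated chain carbon bound to an aromatic nitrogen

For the measured compounds named here, no step between measured compounds isolates a change of this kind, so there is nothing in the data that fixes its size or direction. The account therefore rests on the value of compound 1 alone. Compound 3 is expected to land near compound 1, with a step of a 1.7-fold higher number from compound 1 to compound 3 (0.22 log units; within the scatter) that may not exceed the scatter. Compound 3 is estimated at 25 uM in this assay, within a range from 8 uM to 80 uM.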

Compound 3, concentration for half-maximal effect: 45 uM
The estimate for compound 3 lay 1.8-fold (0.26 log units) below the measured number; measured number inside the range.
By their numbers in this assay, from the lowest: compound 1; then compound 3; then compound 2.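

The step at this position can now be read: in this assay the change from ethyl to 2,3-dihydroxypropyl, which amounts to 1,2-dihydroxyethyl in place of methyl on a saturated chain carbon bound to an aromatic nitrogen, gives a 3.0-fold higher number from compound 1 to compound 3 (0.48 log units; beyond the scatter) and so moves the number upward by a modest amount. The entering group carries 4 heavy atoms against 1 for the methyl it replaces, together with 2 hydrogen-bond donors and 2 hydrogen-bond acceptors, and in this one pair that change raises the concentration needed rather than lowering it. Nothing in the available evidence says which feature of the new chain accounts for this step.

The compounds shown leave open whether the step follows the two hydroxyl groups or the longer chain alone, and a plain propyl chain at this place would separate the two. Also open, from the compounds shown here alone, is how a chain ending in an amine or a carboxylic acid would read in this assay on the shared core.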